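A Nitrile in Place of the Hydroxyamino Group

A few compounds are considered here, and "the series" means these few. Any claim that something is new, unique, unknown or untested is made for them only; others in the source may bear on it.

Of the compounds shown here, three sharing one core have been measured in an assay for inhibition of Tryptophan 2,3-dioxygenase (Homo sapiens), with a stated time of 1 h, tested at 10 uM; a lower number here means less inhibition, a higher number more inhibition at the concentration tested (going by the name of the read-out). Compound 1, `CC(=O)Nc1ccc(CNc2cc(Br)cc3[nH]ncc23)cc1`, gives "not active" (no number reported). Compound 2, `Nc1ccc(CNc2cc(Br)cc3[nH]ncc23)cc1`, gives 24% in this assay. Among the measured compounds shown here, compound 3, `ONc1ccc(CNc2cc(Br)cc3[nH]ncc23)cc1`, gives 6%, the lowest of the two numbers reported, and the step of a number 18 percentage points lower from compound 2 to compound 3 (beyond the scatter) is the only measured step. Compound 4, `N#Cc1ccc(CNc2cc(Br)cc3[nH]ncc23)cc1`, differs from compound 3 by cyano in place of hydroxyamino on an aromatic carbon. For the measured compounds named here, no measured step carries a nitrile, so the single step in hand bears on this change only loosely, and the three measured compounds all sit low. Compound 4 is therefore expected to give 10%, between -5% and 30%, an estimated step of a number 4 percentage points higher from compound 3 to compound 4 (within the scatter).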

Compound 4, a percentage reported as inhibition, at one concentration (the size of the read-out at that concentration, not a potency): 73%
The estimate for compound 4 lay 63 percentage points below the measured number; measured number above the stated range.
By their numbers in this assay, from the lowest: compound 3; then compound 2; then compound 4.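

Among the compounds shown here, the aromatic carbon para to a large group proves able to carry far higher inhibition than the earlier compounds suggested: in this assay, the change to cyano from hydroxyamino gives a number 67 percentage points higher from compound 3 to compound 4 (beyond the scatter), and the change to cyano from amino gives a number 49 percentage points higher from compound 2 to compound 4 (beyond the scatter). The earlier step, between amino and hydroxyamino, gave no hint of a change of this size. Nothing available explains why the nitrile stands out. The compounds shown leave open whether a carboxylic acid, a primary amide or a halogen on this carbon would match the nitrile, and whether the gain would survive replacing the bromine on the shared core.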